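From Thiophen-3-yl to Phenyl at the Assay Limit

The compounds below may be only part of what the source reports. "The series", "measured", "known", "first", "only" and "open" are said of these compounds alone.

Of the compounds shown here, two sharing one core have been tested so far, and neither gives a true number. In a functional assay on HeLa S3 cells (Homo sapiens) for antiproliferative activity, read by XTT assay, with a stated time of 72 h (a lower number here means a stronger inhibitor, a higher number a weaker inhibitor), compound 2 (`CSc1ncnc2c1c(-c1ccsc1)cn2[C@@H]1O[C@H](CO)[C@@H](O)[C@H]1O`) gives > 20000 nM, which is a limit of the assay and not a number. In this assay, compound 1 (`COc1ncnc2c1c(-c1ccccc1)cn2[C@@H]1O[C@H](CO)[C@@H](O)[C@H]1O`) gives > 20000 nM, which is also a limit. Compound 2 therefore has no exact position to start from, and the whole picture so far is the limit of > 20000 nM in this assay, at which 2 of the 2 values shown sit.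

Compound 3 (`CSc1ncnc2c1c(-c1ccccc1)cn2[C@@H]1O[C@H](CO)[C@@H](O)[C@H]1O`) is compound 2 with phenyl in place of thiophen-3-yl on an aromatic carbon. Among the measured compounds shown here, no measured pair shows what a change of this kind does, so the size of the step cannot be read from the data. The expectation is therefore modest: no step beyond the usual scatter in this assay, in either direction. The expected step is a number no higher from compound 2 to compound 3 (the limit leaves the size open). For compound 3, the estimated value is 20000 nM, with an expected range from 6000 nM to 20000 nM.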

Compound 3, half-maximal inhibitory concentration: > 20000 nM
Compound 3 ended at the assay's limit; the forecaster's own chance of this, stated with the estimate: 75%; the middle value lies on the limit itself.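

Neither the step from compound 2 to compound 3 nor the step from compound 1 to compound 3 can be read, because all three compounds stop at the same limit: the limit of > 20000 nM in this assay, at which 3 of the 3 values shown sit.

The compounds shown leave open whether phenyl in place of thiophen-3-yl, or methylsulfanyl in place of methoxy, changes the result in this assay at all, and which change to the shared core would give a true number.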